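The source may report more compounds than this note shows. Statements on the series, on what has been measured and on what is new or still open speak of the compounds shown alone.

Measured compounds:
compound 1 `ClCc1cccc(Cn2cnc3c(Cl)nc(Cl)nc32)c1`, 5010 nM
compound 2 `ClCc1ccccc1Cn1cnc2ncnc(Cl)c21`, 19100 nM

Both compounds were tested in a functional assay on PC-3 cells (Homo sapiens) for cytotoxicity, read by sulforhodamine B assay, with a stated time of 48 h (on this read-out higher numbers stand for weaker inhibition of growth and lower numbers for stronger inhibition of growth), where compound 2 gives 19100 nM and stands highest of the two numbers, meaning the weaker of the pair. Compound 1 gives 5010 nM; the gap between the two is beyond the scatter, so compound 1 is the stronger of the two. Within the data shown here, the two structures differ in more than one place, so no single step between them can be drawn.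

Compound 3 `ClCc1ccccc1Cn1cnc2nc(Cl)nc(Cl)c21` has not yet been measured. It keeps the core and the side chain of compound 2 and differs from it in one place: chloro in place of hydrogen on an aromatic carbon. Among the measured compounds shown here, no measured pair shows this change alone. Compound 1, which also carries two chloro groups on its core, sits well below compound 2, and that points toward a lower number for compound 3, but the other difference between compound 1 and compound 2 leaves the size of that move uncertain. The step from compound 2 to compound 3 is therefore expected to be a moderate gain, a 2.4-fold lower number from compound 2 to compound 3 (0.38 log units; beyond the scatter). Compound 3 is expected to give about 8000 nM, with a range from 3000 nM to 20000 nM.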

Compound 3, concentration for total growth inhibition: 2570 nM
For compound 3 the middle estimate is 3.1-fold (0.49 log units) above the measured one; measured number below the stated range.
By their numbers in this assay, from the lowest: compounds 3 and 1 (each within the scatter of the next); then compound 2.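

In this assay, among these compounds, chloro in place of hydrogen on the aromatic carbon between two ring nitrogen atoms gives a 7.4-fold lower number from compound 2 to compound 3 (0.87 log units; beyond the scatter), the first comparison here in which only one place changes. With the side chain and the rest of the core held the same, this one added heavy atom is enough on its own to move the number beyond the scatter, towards stronger inhibition of growth. No measurement at hand explains the move, so its reason stays unknown.

A single change cannot show whether this gain belongs to chloro in particular or would also come with another group on the same carbon, and an amine, a methoxy group or a fluoro group there would help tell those two readings apart. On these data alone, the chloromethyl group on the side chain is the same in compound 2 and compound 3, so it also remains open whether the gain would hold with a plain methyl group in its place.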